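The source may report more compounds than this note shows. Statements on the series, on what has been measured and on what is new or still open speak of the compounds shown alone.

Measured in a functional assay with Oryctolagus cuniculus as the target; a higher number here means a weaker inhibitor, a lower number a stronger inhibitor:
- compound 1 `COc1ccc(-c2nc(CN(C)C)sc2-c2ccc(OC)cc2)cc1`: 96 nM
- compound 2 `COc1ccc(-c2nc(CNC(=O)N3CCOCC3)sc2-c2ccc(OC)cc2)cc1`: 660 nM
- compound 3 `COc1ccc(-c2nc(C(N)=O)sc2-c2ccc(OC)cc2)cc1`: > 1000 nM, a limit of the assay

Compound 3 has no number, only the limit > 1000 nM.

Compound 4 `COc1ccc(-c2nc(C(=O)N3CCCCC3)sc2-c2ccc(OC)cc2)cc1` differs from it by piperidin-1-yl in place of amino on a carbonyl carbon. For the measured compounds named here, no measured step changes this group. The nearest are an at least 10-fold higher number from compound 1 to compound 3 (1.01 log units; beyond the scatter) and an at least 1.5-fold higher number from compound 2 to compound 3 (0.18 log units; that floor lies within the scatter). Going by the values given here, both end at the limit, so they fix no size for a step leaving compound 3. The step of a 6.9-fold higher number from compound 1 to compound 2 (0.84 log units; beyond the scatter) concerns a different attachment.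

In this assay, no clear change is therefore expected, and the expected step is a step that the limit leaves unreadable from compound 3 to compound 4. Compound 4 is estimated at 1200 nM, with an expected range of 300 nM to 5000 nM.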

Compound 4, half-maximal inhibitory concentration: > 1000 nM
Compound 4 was reported as a limit (the forecaster's own chance of this, stated with the estimate: 45%); the middle value lies beyond the limit too.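

In this assay compound 4 gives > 1000 nM, which is a limit of the assay, so piperidin-1-yl on the carbonyl carbon yields no measurable value here, just as amino did. The step from compound 3 cannot be read because both compounds sit at that limit: the limit of > 1000 nM in this assay, at which 2 of the 4 values shown sit.

The readable steps are an at least 10-fold higher number from compound 1 to compound 4 (1.01 log units; beyond the scatter) and an at least 1.5-fold higher number from compound 2 to compound 4 (0.18 log units; that floor lies within the scatter).

On these data alone, it remains open whether diethylamino or pyrrolidin-1-yl on the saturated chain carbon would keep the value of compound 1, 96 nM.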